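Trimming the amide cap on a chalcone-type inhibitor series

The compounds below may be only part of what the source reports. "The series", "measured", "known", "first", "only" and "open" are said of these compounds alone.

Of the compounds shown here, three sharing one core have been measured in a functional assay on U-87MG ATCC cells (Homo sapiens) for inhibition; a higher number here means a weaker inhibitor, a lower number a stronger inhibitor. Compound 1 `COC(=O)C(=O)Nc1cccc(C(=O)/C=C/c2ccc(O)c(OC)c2)c1` gives 12.2 ug/mL in this assay. Compound 2 `COc1cc(/C=C/C(=O)c2cccc(NC(=O)c3cccs3)c2)ccc1O` gives 14.7 ug/mL, and a 1.2-fold higher number from compound 1 to compound 2 (0.08 log units; within the scatter). Compound 3 `COc1cc(/C=C/C(=O)c2cccc(NC(=O)c3ccc(Cl)cc3Cl)c2)ccc1O` returns only a limit of the assay, > 50 ug/mL, so its number is not known; it sits at the limit of > 50 ug/mL in this assay, at which 1 of the 3 values shown sits. Against the two other compounds this means an at least 4.0-fold higher number from compound 1 to compound 3 (0.61 log units; beyond the scatter) and an at least 3.4-fold higher number from compound 2 to compound 3 (0.53 log units; beyond the scatter), so compound 3 stands as the weakest of the three on the numbers shown.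

Compound 4 `COc1cc(/C=C/C(=O)c2cccc(NC(C)=O)c2)ccc1O` is not yet measured. It differs from compound 3 by methyl in place of 2,4-dichlorophenyl on a carbonyl carbon. For the measured compounds named here, the steps that bear on this change are those from compound 1 and compound 2 to compound 3, where a smaller group on that carbonyl carbon went with a lower number in this assay. A step back toward lower numbers is therefore expected for compound 4, roughly the size of those two steps, that is an at least 3.8-fold lower number from compound 3 to compound 4 (0.58 log units; beyond the scatter). Compound 4 is estimated at 13 ug/mL in this assay, expected to lie between 5 ug/mL and 40 ug/mL.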

Compound 4, half-maximal inhibitory concentration: > 50 ug/mL
Compound 4 gave a limit, no number; the forecaster's own chance of this, stated with the estimate: 20%; middle value at least 3.8-fold (0.58 log units) from the limit.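

In this assay compound 4 returns only a limit, > 50 ug/mL, and not a number. The methyl cap still gives an at least 3.4-fold higher number from compound 2 to compound 4 (0.53 log units; beyond the scatter) and an at least 4.0-fold higher number from compound 1 to compound 4 (0.61 log units; beyond the scatter), so on this carbonyl carbon the smallest group shown does not join the thiophen-2-yl and methoxycarbonyl compounds. The step between compound 3 and compound 4 cannot be read, but compound 4 goes against the link between a smaller group and a lower number, with methyl and 2,4-dichlorophenyl both ending at the limit: the limit of > 50 ug/mL in this assay, at which 2 of the 4 values shown sit.

As far as these compounds go, how far compound 3 and compound 4 truly differ remains open, since neither has a number. Also open, from the compounds shown here alone, is whether a carboxylic acid, a furan-2-yl or an ethyl group on this carbonyl carbon would give values like those of compound 1 and compound 2.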